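This account rests on a few compounds, and the source may have more. Where it says the series, first, only, none or still open, it means among the compounds named here.

Compound 3 `CCCn1c(-c2ccco2)nc2c(N)nc(NCc3ccccc3)nc21` is one of three analogues sharing a core with an amino group and a substituted amine on one ring. In a functional assay on CHO cells for antagonist activity at adenosine receptor A2b (Homo sapiens) (a lower number here means a stronger inhibitor, a higher number a weaker inhibitor), compound 3 gives 4610 nM. Compound 2 `CCCn1c(Br)nc2c(N)nc(NCCCc3ccccc3)nc21` carries a bromine on the core and a longer chain; in this assay compound 2 gives 6300 nM, which lies within the scatter of compound 3. Compound 1 `CCCn1cnc2c(N)nc(NCCCc3ccccc3)nc21` has hydrogen where compound 2 has bromine, and in this assay compound 1 reaches only a limit, > 30000 nM, consistent with the limit of > 30000 nM in this assay, at which 1 of the 3 values shown sits. Going by the values given here, the single measured step, an at least 4.7-fold lower number from compound 1 to compound 2 (0.67 log units; beyond the scatter), concerns that bromine and not the chain.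

Compound 4 `CCCn1c(-c2ccco2)nc2c(N)nc(NCCCc3ccccc3)nc21` differs from compound 3 in one place: phenethyl in place of phenyl on a saturated chain carbon bound to a nitrogen on an aromatic ring. Among the compounds with values here, no measured pair isolates this lengthening; compounds 2 and 3 differ both in the chain and in the core substituent, so their values cannot be split between the two. The expectation for compound 4 therefore rests on the similar numbers of compounds 2 and 3, and the step of a 1.8-fold lower number from compound 3 to compound 4 (0.27 log units; within the scatter) is expected to stay within the scatter. Compound 4 is estimated at 2500 nM in this assay, with a range from 600 nM to 12000 nM.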

Compound 4, inhibition constant: 8240 nM
Compound 4: middle estimate off by 3.3-fold (0.52 log units), on the low side, within the range that was stated.
By their numbers in this assay, from the lowest: compounds 3, 2 and 4 (each within the scatter of the next). At a limit, above all of these: compound 1.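

Going by these compounds alone, compound 3 and compound 4 share furan-2-yl on the core, so this pair isolates the chain for the first time, and going from benzyl to 3-phenylpropyl gives a 1.8-fold higher number from compound 3 to compound 4 (0.25 log units; within the scatter), which means that in this assay this lengthening has no effect that can be told from the scatter. With the 3-phenylpropyl chain held fixed, the exchange on the aromatic carbon gives a 1.3-fold higher number from compound 2 to compound 4 (0.12 log units; within the scatter), so bromo and furan-2-yl cannot be told apart here. Furan-2-yl in place of hydrogen gives an at least 3.6-fold lower number from compound 1 to compound 4 (0.56 log units; beyond the scatter), which makes it the second group on that carbon, after bromo, to go with a lower number than hydrogen, and the true size of this step stays unknown, as the starting value is a limit: the limit of > 30000 nM in this assay, at which 1 of the 4 values shown sits.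

The compounds shown leave open whether an amine or a carboxylic acid on that aromatic carbon, or a chain longer than 3-phenylpropyl, would move the number beyond the scatter. They also leave open whether the chain change would read the same with bromo or hydrogen on the core, as only furan-2-yl is shown with both chains.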